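A few compounds are considered here, and "the series" means these few. Any claim that something is new, unique, unknown or untested is made for them only; others in the source may bear on it.

The series varies one group on a carbonyl carbon of a shared core, and the only read-out is a functional assay on the whole organism with Mus musculus as the target; a lower number here means that less compound is needed, a higher number that more compound is needed for the effect. Compound 1 (`CNC(=O)Cn1c(-c2ccc(Cl)cc2)nc2cccnc21`) gives 12.5 mg/kg, compound 2 (`O=C(Cn1c(-c2ccc(Cl)cc2)nc2cccnc21)N1CCCCC1`) gives 56.2 mg/kg and compound 3 (`CCOC(=O)CCCNC(=O)Cn1c(-c2ccc(Cl)cc2)nc2cccnc21`) gives 100 mg/kg. The upper end of this range is where compound 3 stands, and there a 1.8-fold higher number from compound 2 to compound 3 (0.25 log units; within the scatter) gives no separation.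

Compound 4 (`CN(C)CCN(C)C(=O)Cn1c(-c2ccc(Cl)cc2)nc2cccnc21`) carries (2-(dimethylamino)ethyl)(methyl)amino in place of (3-(ethoxycarbonyl)propyl)amino on a carbonyl carbon. The closest guide is a 1.8-fold higher number from compound 2 to compound 3 (0.25 log units; within the scatter), an exchange at the same carbonyl carbon. The two clear gaps, a 4.5-fold higher number from compound 1 to compound 2 (0.65 log units; beyond the scatter) and an 8.0-fold higher number from compound 1 to compound 3 (0.90 log units; beyond the scatter), both start from methylamino, and both replacements gave higher numbers. Among the compounds with values here, no measured step covers the entering group itself, so the estimate rests on these three steps alone. No step beyond the scatter is expected in this assay. The expected step is a 1.4-fold lower number from compound 3 to compound 4 (0.15 log units; within the scatter). For compound 4 the estimated value is 70 mg/kg, with an expected range of 25 mg/kg to 160 mg/kg.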

Compound 4, dose for half-maximal effect: 100 mg/kg
The estimate for compound 4 lay 1.4-fold (0.15 log units) below the measured number, and the stated range covers the measured number.
By their numbers in this assay, from the lowest: compound 1; then compounds 2, 3 and 4 (each within the scatter of the next).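

In this assay, (2-(dimethylamino)ethyl)(methyl)amino in place of (3-(ethoxycarbonyl)propyl)amino on the carbonyl carbon gives no change at the digits printed from compound 3 to compound 4 (within the scatter), although the entering group has no ester and no amide hydrogen, and the comparison with piperidin-1-yl gives a 1.8-fold higher number from compound 2 to compound 4 (0.25 log units; within the scatter). A ring and two quite different open chains at this carbonyl carbon therefore stand within the scatter of each other, while the only clear gap is still the one from methylamino, seen again as an 8.0-fold higher number from compound 1 to compound 4 (0.90 log units; beyond the scatter). Nothing available explains why these three groups fall together. Open, on these data alone, is how the unsubstituted amino group, ethylamino or dimethylamino would read here, which would test whether the low number is tied to methylamino alone. Also open, as far as these compounds go, is whether a carboxylic acid in place of the ethyl ester of compound 3 would separate from it.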